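A few compounds are considered here, and "the series" means these few. Any claim that something is new, unique, unknown or untested is made for them only; others in the source may bear on it.

Compound 1 `O=CN1CCN(c2ccc(Cl)cc2)C1=S`: 15900 nM
Compound 2 `N#C/C(=C\N1CCN(C(=O)c2ccco2)C1=S)C(N)=O`: 14000 nM
Compound 3 `O=CN1CCN(C(=O)c2ccco2)C1=S`: 5000 nM

In a functional assay on UACC-62 cells (Homo sapiens) for inhibition, read by sulforhodamine B assay, with a stated time of 48 h (on this read-out lower numbers stand for stronger inhibition of growth and higher numbers for weaker inhibition of growth), compound 2 gives 14000 nM, which places it among the higher numbers of the three. Compound 1 gives 15900 nM, a number within the usual scatter of that of compound 2, so the two cannot be told apart. Compound 3 gives 5000 nM, a lower number than compound 2 by a margin beyond the scatter.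

Compound 4 `N#C/C(=C\N1CCN(C(=O)c2ccco2)C1=S)C(=O)Nc1ccc(Cl)cc1` has not been measured. It differs from compound 2 in one place: 4-chlorophenyl in place of hydrogen on an amide-type nitrogen. No single-change step between measured compounds is available to set a scale for this change, so the size of the step is uncertain; on the three numbers shown, a modest move toward a lower number in this assay is expected, of a size that may not clear the scatter.

For compound 4 the estimate in this assay is 7000 nM, with a range from 2500 nM to 20000 nM, meaning an expected step of a 2.0-fold lower number from compound 2 to compound 4 (0.30 log units; within the scatter).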

Compound 4, concentration for 50% growth inhibition: 16900 nM
Compound 4: the middle estimate sits 2.4-fold (0.38 log units) below what was measured, within the range that was stated.
By their numbers in this assay, from the lowest: compound 3; then compounds 2, 1 and 4 (each within the scatter of the next).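

In this assay the amide-type nitrogen of compound 2 takes a 4-chlorophenyl group in place of hydrogen, with a 1.2-fold higher number from compound 2 to compound 4 (0.08 log units; within the scatter) as the outcome. Within the data shown here, this is the first single-change step at this position, and it shows that the amide hydrogen and the 4-chlorophenyl group cannot be told apart on this read-out, something the earlier compounds, linked by no such step, could not show. Nothing measured here accounts for the size of this step.

Among these compounds, with only one group beyond hydrogen on this nitrogen, it remains open whether the same holds for a methyl group, a longer alkyl chain, an unsubstituted phenyl or a carboxylic acid-bearing ring. From the compounds shown here alone, it also remains open whether the step would read the same on other cell lines.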